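Adding ethyl to a polar propargylic ether chain

The source may report more compounds than this note shows. Statements on the series, on what has been measured and on what is new or still open speak of the compounds shown alone.

Compound 1 `C#CC(C)OC[n+]1ccn(C)c1/C=N/O`: -2.14
Compound 2 `CC#CC(C)OC[n+]1ccn(C)c1/C=N/O`: -1.74

Within the data shown here, in a physicochemical assay for lipophilicity (a higher number here means a more lipophilic compound, a lower number a more polar compound), compound 1 gives -2.14, the lower of the two numbers measured so far. Compound 3 `C#CC(CCC)OC[n+]1ccn(C)c1/C=N/O` has yet to be measured. Its difference from compound 1 is ethyl in place of hydrogen on a saturated chain carbon, two bonds along the chain from an oxygen on a saturated carbon and a triple-bonded carbon, which can also be read as methyl to propyl on the same chain. Among the measured compounds shown here, only one measured step bears on this change: a number 0.40 log units higher from compound 1 to compound 2 (beyond the scatter). That step is modest but beyond the scatter, and it places methyl in place of hydrogen on a triple-bonded carbon, so it falls elsewhere on the chain. With a single step at a different place, the guide is weak. An upward move somewhat larger than that step is nevertheless expected, since ethyl enters here where methyl entered there. The expected step is a number 0.79 log units higher from compound 1 to compound 3 (beyond the scatter). Compound 3 is estimated at -1.35, within an expected range from -1.75 to -0.95.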

Compound 3, distribution coefficient: -1.1
Beside the measured number, compound 3's estimate is 0.25 log units below it; low and high end bracket the measured number.
By their numbers in this assay, from the lowest: compound 1; then compound 2; then compound 3.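

In this assay the saturated chain carbon proves a responsive place, as ethyl in place of hydrogen there gives a number 1.04 log units higher from compound 1 to compound 3 (beyond the scatter) on the scale of this series. Among these compounds, the only earlier step, a number 0.40 log units higher from compound 1 to compound 2 (beyond the scatter) at the triple-bonded carbon, was modest, so the chain now shows a large step at one place and a modest one at another. No measurement shown here accounts for the size of either step.

The compounds shown leave open whether a longer chain such as butyl on this carbon would continue the rise or whether it levels off beyond propyl. They also leave open whether a hydroxyl or an amine at the end of the propyl chain would take back the gain, and whether methyl on the triple-bonded carbon would add to it.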